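Notes on the amine substituent: compound 3 to compound 4

A few compounds are considered here, and "the series" means these few. Any claim that something is new, unique, unknown or untested is made for them only; others in the source may bear on it.

Measured so far in an assay on isolated protein for inhibition of ubiquitin carboxyl-terminal hydrolase 7 (Homo sapiens), with stated times of 30 min and 2 h; on this read-out lower numbers stand for stronger inhibition and higher numbers for weaker inhibition:
compound 1 `Cn1nc2c(=O)n(CC3(O)CCN(Cc4ccc(-c5cccs5)cc4Cl)CC3)cnc2c1-c1ccc(CN)cc1`: 38.6 nM
compound 2 `Cn1nc2c(=O)n(CC3(O)CCN(Cc4ccc(-c5ccncc5)cc4Cl)CC3)cnc2c1-c1ccc(CN)cc1`: 257 nM
compound 3 `Cn1nc2c(=O)n(CC3(O)CCN(Cc4ccc(-c5ccco5)cc4Cl)CC3)cnc2c1-c1ccc(CNC2CC2)cc1`: 54.1 nM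

Compound 3 stands second highest of the three numbers; its nearest neighbour is compound 1, within the scatter, and compound 2 is furthest, beyond it. For the measured compounds named here, the only measured step, a 6.7-fold higher number from compound 1 to compound 2 (0.82 log units; beyond the scatter), concerns the aromatic substituent and not the amine, so it does not bear on the change at hand.

Compound 4 `Cn1nc2c(=O)n(CC3(O)CCN(Cc4ccc(-c5ccco5)cc4Cl)CC3)cnc2c1-c1ccc(CN)cc1` differs from compound 3 by hydrogen in place of cyclopropyl on an amine nitrogen. Going by the values given here, no measured pair varies the amine nitrogen, so no step is expected beyond the scatter, a 1.2-fold lower number from compound 3 to compound 4 (0.08 log units; within the scatter). Compound 4 is estimated at 45 nM, in the range 20 nM to 110 nM.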

Compound 4, half-maximal inhibitory concentration: 18.1 nM
Compound 4: the middle estimate sits 2.5-fold (0.40 log units) above what was measured; the measured number lies below the stated range.
By their numbers in this assay, from the lowest: compound 4; then compounds 1 and 3 (each within the scatter of the next); then compound 2.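

In this assay, hydrogen in place of cyclopropyl on the amine nitrogen gives a 3.0-fold lower number from compound 3 to compound 4 (0.48 log units; beyond the scatter), the first read on this position, and it shows that with furan-2-yl held fixed the aminomethyl form gives the lower number. With aminomethyl held fixed, the aromatic substituent still moves the number, with a 2.1-fold lower number from compound 1 to compound 4 (0.33 log units; beyond the scatter) and a larger 14-fold lower number from compound 2 to compound 4 (1.15 log units; beyond the scatter). Nothing at hand explains either change.

On these data alone, whether the amine step carries over to the thiophen-2-yl or pyridin-4-yl compounds remains open. Also open, as far as these compounds go, is how a methylamino or dimethylamino group would read at this nitrogen.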